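A few compounds are considered here, and "the series" means these few. Any claim that something is new, unique, unknown or untested is made for them only; others in the source may bear on it.

Measured so far: compound 1 `CCN(CC)CCNC(=O)c1ccc(C(CC)(CC)c2ccc(OCC(O)C(C)(C)C)c(C)c2)n1CC` gives 2310 nM; compound 2 `CCn1c(C(=O)NCCCN(C)C)ccc1C(CC)(CC)c1ccc(OCC(O)C(C)(C)C)c(C)c1` gives 1900 nM.

Compound 1 stands highest of the two numbers in a functional assay on Caco-2 cells (Homo sapiens), read by MTT assay, with a stated time of 48 h; on this read-out lower numbers stand for stronger inhibition and higher numbers for weaker inhibition; its nearest neighbour is compound 2, and a 1.2-fold lower number from compound 1 to compound 2 (0.08 log units; within the scatter), so the two are not separated. Compound 3 `CCn1c(C(=O)N(C)CC(=O)O)ccc1C(CC)(CC)c1ccc(OCC(O)C(C)(C)C)c(C)c1` is not yet measured. It differs from compound 1 as (carboxymethyl)(methyl)amino in place of (2-(diethylamino)ethyl)amino on a carbonyl carbon. Going by the values given here, no measured step bears directly on this replacement at the carbonyl carbon; the single step shows only that a change further out along the chain stays within the scatter. For compound 3 a modest shift to a higher number is expected, a 1.9-fold higher number from compound 1 to compound 3 (0.29 log units; within the scatter), giving an estimate of 4500 nM with a range of 1500 nM to 15000 nM.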

Compound 3, half-maximal inhibitory concentration: 31900 nM
Compound 3: middle estimate off by 7.1-fold (0.85 log units), on the low side; measured number above the stated range.
By their numbers in this assay, from the lowest: compounds 2 and 1 (each within the scatter of the next); then compound 3.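

On the carbonyl carbon, a 14-fold higher number from compound 1 to compound 3 (1.14 log units; beyond the scatter) and a 17-fold higher number from compound 2 to compound 3 (1.23 log units; beyond the scatter) both lie beyond the scatter in this assay for the change to (carboxymethyl)(methyl)amino. Going by these compounds alone, the earlier step, confined to the diethylamino end of the chain, stayed within the scatter, so this replacement is the first change to separate compounds. No measurement at hand accounts for the size of these steps.

The compounds shown alter the chain end, chain length and amide hydrogen together, leaving their shares unseparated. Going by these compounds, how a methyl ester in place of the carboxylic acid would read remains open.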